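Ethoxy to isopropoxy at the limit of the assay

This account rests on a few compounds, and the source may have more. Where it says the series, first, only, none or still open, it means among the compounds named here.

Measured so far in a functional assay on HepG2 cells (Homo sapiens) for inhibition, read by MTT assay, with a stated time of 72 h; a lower number here means a stronger inhibitor, a higher number a weaker inhibitor
- compound 1 `Cc1ccccc1-c1cc(C(=O)N2CCC3(CC2)CC(=O)c2nn(C(C)(C)C)cc2O3)c2ccccc2n1` gives > 10000 nM as a limit
- compound 2 `CCOc1cc(C(=O)N2CCC3(CC2)CC(=O)c2nn(C(C)(C)C)cc2O3)c2ccccc2n1` gives > 10000 nM as a limit

Compound 2 stands at > 10000 nM in this assay, which is a limit and not a number. Compound 3 `CC(C)Oc1cc(C(=O)N2CCC3(CC2)CC(=O)c2nn(C(C)(C)C)cc2O3)c2ccccc2n1` differs from compound 2 by methyl in place of hydrogen on a saturated chain carbon bound to an oxygen on an aromatic ring and a saturated chain carbon in the form of methyl in place of hydrogen on a saturated chain carbon bound to an oxygen on an aromatic ring and a saturated chain carbon, so that ethoxy becomes isopropoxy. Among the measured compounds shown here, the one measured step that bears on this is a step that the two limits leave unreadable from compound 1 to compound 2 for ethoxy in place of 2-methylphenyl on an aromatic carbon, and it offers no size to carry over. The evidence amounts to the limit of > 10000 nM in this assay, at which 2 of the 2 values shown sit, and the series holds no numeric potency yet. With compound 2 at > 10000 nM as a limit, no step beyond the scatter and no direction is expected in this assay. The expected step is a step that the limit leaves unreadable from compound 2 to compound 3 as an estimate only. For compound 3 the estimated value is 15000 nM with an expected range from 8000 nM to 40000 nM and a report of only a limit is the likeliest outcome.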

Compound 3, half-maximal inhibitory concentration: 3150 nM
The estimate for compound 3 lay 4.8-fold (0.68 log units) above the measured number, outside the stated range (below it).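

In this assay, the series gains its first numeric potency from one added methyl on a saturated chain carbon bound to an oxygen on an aromatic ring: ethoxy to isopropoxy gives an at least 3.1-fold lower number from compound 2 to compound 3 (0.50 log units; beyond the scatter). At the same aromatic carbon, isopropoxy in place of 2-methylphenyl gives an at least 3.1-fold lower number from compound 1 to compound 3 (0.50 log units; beyond the scatter), so isopropoxy is the only one of the three groups shown there that brings a number within the range of the assay. Both steps start from a limit and therefore fix only a smallest size, the step between the two limit compounds cannot be read, and the rest of the series still sits at that limit: the limit of > 10000 nM in this assay, at which 2 of the 3 values shown sit.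

With only three compounds shown, it remains open whether the lower number depends on the extra methyl on that carbon as such or would also follow from a longer chain such as n-propoxy or a larger group such as tert-butoxy or cyclopentyloxy. Going by these compounds, it is equally open how an amine or a carboxylic acid at the end of the chain on that oxygen would read in this assay.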